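This account rests on a few compounds, and the source may have more. Where it says the series, first, only, none or still open, it means among the compounds named here.

Among the compounds with values here, in a functional assay on L1210 cells (Mus musculus) for inhibition, with a stated time of 96 h (a higher number here means a weaker inhibitor, a lower number a stronger inhibitor), compound 3 (`CCNCCCCNCCCN`) gives 40000 nM, the highest of the three numbers measured so far. Compound 1 (`CCNCCCNCCCNCC`) gives 10000 nM and compound 2 (`CCNCCCNCCCCN`) gives 4000 nM, which makes compound 3 the weakest inhibitor of the set. Compound 4 (`CCNCCCCNCCCNCC`) differs from compound 3 by a single change, ethyl in place of hydrogen on an amine nitrogen.

Within the data shown here, only one measured step involves an ethyl-bearing amine: a 2.5-fold lower number from compound 1 to compound 2 (0.40 log units; beyond the scatter), with aminomethyl in place of ethylamino on a saturated chain carbon. This is a different change, and on its own it would hint that adding ethyl raises the number slightly. Pointing the other way, compound 4 has no aminomethyl group, and neither does compound 1, which stands at 10000 nM. That resemblance carries more weight, so a lower number is expected, with an estimated change of a 5.0-fold lower number from compound 3 to compound 4 (0.70 log units; beyond the scatter). For compound 4 the expected value is 8000 nM, with an estimated range of 2500 nM to 30000 nM.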

Compound 4, half-maximal inhibitory concentration: 700 nM
The estimate for compound 4 lay 11-fold (1.06 log units) above the measured number; measured number below the stated range.
By their numbers in this assay, from the lowest: compound 4; then compound 2; then compound 1; then compound 3.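

In this assay, ethyl in place of hydrogen on an amine nitrogen gives a 57-fold lower number from compound 3 to compound 4 (1.76 log units; beyond the scatter) as a large step, the first measured result for this change, and it also gives a 5.7-fold lower number from compound 2 to compound 4 (0.76 log units; beyond the scatter) as a modest one. Extending the group on the saturated chain carbon, three bonds along the chain from an amine nitrogen, from ethylamino to (ethylamino)methyl gives a 14-fold lower number from compound 1 to compound 4 (1.15 log units; beyond the scatter), which makes compound 4 the strongest inhibitor of the four, with all its steps beyond the scatter. Nothing available here accounts for the size of these steps.

On these data alone, it remains open whether a methyl group or a longer chain such as propyl on that amine nitrogen would lower the number as far as ethyl does. As far as these compounds go, a benzyl group in the same place is equally open.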